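Branching the alkyl chain on the shared core

This account rests on a few compounds, and the source may have more. Where it says the series, first, only, none or still open, it means among the compounds named here.

Compound 1 `CCCCOc1nc(N)nc2[nH]cnc12` is the reference point. Within the data shown here, in an assay on HT-29 cells for inhibition of Methylated-DNA--protein-cysteine methyltransferase (Homo sapiens) (on this read-out higher numbers stand for weaker inhibition and lower numbers for stronger inhibition), compound 1 gives 493000 nM, the lowest of the two numbers measured so far. Among the measured compounds shown here, its only neighbour is compound 2 `Nc1nc(OCCc2ccccc2)c2nc[nH]c2n1`, which in this assay gives 548000 nM; the change is a 1.1-fold higher number from compound 1 to compound 2 (0.05 log units; within the scatter). Compound 3 `C=C(CC)COc1nc(N)nc2[nH]cnc12` has not been measured. It differs from compound 1 by a group of 4 heavy atoms (4 carbon; no ring) in place of a group of 3 heavy atoms (3 carbon; no ring), on a saturated chain carbon bound to an oxygen on an aromatic ring. For the measured compounds named here, the one measured step, which swaps a phenyl for an ethyl two bonds further along the chain, leaves the number essentially unchanged, and it touches a different place from the one altered here, so it says little about a branched, unsaturated chain directly on the carbon bound to the oxygen. Going by the values given here, with no step bearing directly on this change, no shift beyond the scatter is expected, so the step from compound 1 to compound 3 is estimated as a 1.2-fold lower number from compound 1 to compound 3 (0.09 log units; within the scatter). For compound 3 the estimate in this assay is 400000 nM, with a range from 120000 nM to 1200000 nM.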

Compound 3, half-maximal inhibitory concentration: 16000 nM
Beside the measured number, compound 3's estimate is 25-fold (1.40 log units) above it; measured number outside the range, below it.
By their numbers in this assay, from the lowest: compound 3; then compounds 1 and 2 (each within the scatter of the next).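

The place on a saturated chain carbon bound to an oxygen on an aromatic ring turns out to be sensitive: swapping the propyl for the group of 4 heavy atoms (4 carbon), which carries a double bond outside aromatic rings, gives a 31-fold lower number from compound 1 to compound 3 (1.49 log units; beyond the scatter) in this assay and so yields stronger inhibition. The earlier change gave only a 1.1-fold higher number from compound 1 to compound 2 (0.05 log units; within the scatter) and revealed no such sensitivity, so the chain can matter greatly even though neither the propyl nor the group that replaces it has any hydrogen-bond donors, hydrogen-bond acceptors or net charge. No measured evidence is available to explain this large step.

The new group differs from propyl in both its branching and its double bond, so these compounds cannot separate the two features. A saturated branched chain such as 2-methylbutyl, or a straight butenyl chain, would be needed to tell them apart.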